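The compounds below may be only part of what the source reports. "The series", "measured", "known", "first", "only" and "open" are said of these compounds alone.

Measured so far in an assay on isolated protein with Bile acid receptor (Homo sapiens) as the target; a higher number here means that more compound is needed for the effect, a lower number that less compound is needed:

Compound 1 `COC(=O)/C=C/c1cccc(N(Cc2ccc(/C=C/c3ccccc3F)cc2)C(=O)NC(C)C)c1` gives 431 nM.
Compound 2 `COC(=O)/C=C/c1cccc(N(Cc2ccc(/C=C/c3ccccn3)cc2)C(=O)C(C)C)c1` gives 310 nM.
Compound 3 `COC(=O)/C=C/c1cccc(N(C)C(=O)C2CCCCC2)c1` gives > 1000 nM, which is a limit of the assay and not a number.

Compound 3 therefore stands at the weak end of these three: for it the assay reports only a limit, so only that it needs more compound than the limit allows is known, as shown by the limit of > 1000 nM in this assay, at which 1 of the 3 values shown sits. Compound 1 and compound 2, by contrast, each gave a measured number.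

Compound 4 `COC(=O)/C=C/c1cccc(N(Cc2cccc(Br)c2)C(=O)C2CCCCC2)c1` has not yet been measured. It differs from compound 3 in one place: 3-bromophenyl in place of hydrogen on a saturated chain carbon bound to an amide-type nitrogen. For the measured compounds named here, no two measured compounds differ in exactly one place, so no measured step guides this change directly. Still, the step from compound 3 to compound 4 is expected to lower the number in this assay, by about an at least 1.4-fold lower number from compound 3 to compound 4 (0.15 log units; that floor lies within the scatter), since compound 1 and compound 2, the two compounds with a measured value, both sit well below the limit. For compound 4 the estimate is 700 nM, with a range from 200 nM to 3000 nM.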

Compound 4, half-maximal effective concentration: > 1000 nM
Compound 4: a limit, no number (the forecaster's own chance of this, stated with the estimate: 35%); middle value at least 1.4-fold (0.15 log units) from the limit.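

Compound 3 and compound 4 each give only a limit of the assay and not a number, so no step can be read between them: the limit of > 1000 nM in this assay, at which 2 of the 4 values shown sit. The compounds shown leave open whether 3-bromophenyl in place of hydrogen changes the result in this assay at all.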